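The compounds below may be only part of what the source reports. "The series", "measured", "known", "first", "only" and "open" are said of these compounds alone.

Compound 1 `CC(=O)NCC#CCn1ccnc1` and compound 2 `CC(=O)NCC#CCn1cncc1C` share one core, compound 3 `CN(C)C(=O)N(C)CC#CCn1ccnc1` carries another, and compound 4 `Cc1cncn1CC#CCN(C)C(=O)N(C)C` is the still unmeasured counterpart of compound 3. In a functional assay on the whole organism for agonist activity, with Mus musculus as the target (on this read-out higher numbers stand for an effect only at larger amounts of compound and lower numbers for an effect already at smaller amounts), compound 1 gives only a limit of the assay, > 100 mg/kg. Compound 2 likewise gives only a limit, > 100 mg/kg. Compound 3 gives 25.4 mg/kg in this assay. The change methyl in place of hydrogen on an aromatic carbon thus yields a step that the two limits leave unreadable from compound 1 to compound 2, which rests on (the limit of > 100 mg/kg in this assay, at which 2 of the 3 values shown sit). The difference between the cores of compound 1 and compound 3 is not broken down here. Compound 4 carries the same kind of change, (methyl in place of hydrogen on an aromatic carbon), though here the ring atom bears a large group rather than a group of 8 heavy atoms. Because the step that the two limits leave unreadable from compound 1 to compound 2 leaves its size unreadable, only a small step is expected, a 1.2-fold higher number from compound 3 to compound 4 (0.07 log units; within the scatter). Compound 4 is therefore estimated at 30 mg/kg, between 10 mg/kg and 100 mg/kg.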

Compound 4, dose for half-maximal effect: > 100 mg/kg
Compound 4: a limit, no number; the forecaster's own chance of this, stated with the estimate: 25%; middle value at least 3.3-fold (0.52 log units) away from the limit.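

On the core of compound 3, methyl in place of hydrogen on an aromatic carbon gives an at least 3.9-fold higher number from compound 3 to compound 4 (0.59 log units; beyond the scatter) in this assay, so here the change moves the read-out beyond the scatter. On the core of compound 1 the same change cannot be read, so the two cores cannot be compared and nothing shows whether the step carries from one to the other. Its full size also remains unknown, because compound 4 gives only a limit: the limit of > 100 mg/kg in this assay, at which 3 of the 4 values shown sit.

The compounds shown leave open whether the step belongs to methyl alone or would also appear with an ethyl group or a chlorine atom at this place. They also leave open how either core would respond to a hydroxymethyl group there.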